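The source may report more compounds than this note shows. Statements on the series, on what has been measured and on what is new or still open speak of the compounds shown alone.

Measured so far:
compound 1 `Cc1c(C(=O)N/N=C\c2ccccc2C(F)(F)F)oc2cccc(O)c12` — 26200 nM
compound 2 `Cc1c(C(=O)N/N=C\c2c(O)cccc2Cl)oc2cccc(O)c12` — 18700 nM
compound 3 `Cc1c(C(=O)N/N=C\c2cccc(F)c2O)oc2cccc(O)c12` — 12700 nM

In a functional assay on PC-3 cells (Homo sapiens) for inhibition (a higher number here means a weaker inhibitor, a lower number a stronger inhibitor), compound 3 gives the lowest of the three numbers. Compound 2 stands nearest to it, and the difference between the two a 1.5-fold lower number from compound 2 to compound 3 (0.17 log units; within the scatter) lies within the scatter, so no order between compound 2 and compound 3 can be read. Compound 1, which carries a trifluoromethyl group and no hydroxyl on its outer ring, gives a number that is beyond the scatter from that of compound 3.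

Compound 4 `Cc1c(C(=O)N/N=C\c2ccccn2)oc2cccc(O)c12` differs from compound 3 in one place: pyridin-2-yl in place of 3-fluoro-2-hydroxyphenyl on a carbon with a double bond to nitrogen. For the measured compounds named here, no measured step covers this exchange directly. Going by the values given here, the only step that bears on it is the one from compound 2 to compound 3, and that one is within the scatter; the comparison of compound 1 with compound 3 shows that the one measured ring without a hydroxyl gives the highest number. On that ground the step from compound 3 to compound 4 is expected to run toward a higher number, roughly a 2.0-fold higher number from compound 3 to compound 4 (0.29 log units; within the scatter). Compound 4 is therefore estimated at 25000 nM in this assay, with a range from 10000 nM to 60000 nM.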

Compound 4, half-maximal inhibitory concentration: >= 40000 nM
Compound 4: only a limit was reported; the forecaster's own chance of this, stated with the estimate: 15%; at least 1.6-fold (0.20 log units) between middle value and limit.
By their numbers in this assay, from the lowest: compounds 3, 2 and 1 (each within the scatter of the next, the first and the last beyond it). At a limit, above all of these: compound 4.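

For the compounds shown here, at the position on the carbon with a double bond to nitrogen, the only earlier step between measured compounds stayed within the scatter, so it could not show that the outer ring matters in this assay. Pyridin-2-yl gives the first steps there that lie beyond the scatter, against both hydroxyl-bearing rings (an at least 3.1-fold higher number from compound 3 to compound 4 (0.49 log units; beyond the scatter); an at least 2.1-fold higher number from compound 2 to compound 4 (0.33 log units; beyond the scatter)). Compound 4 gives no number, only a limit, so both steps set a minimum size: the limit of >= 40000 nM in this assay, at which 1 of the 4 values shown sits.

The exchange changes the ring atoms and removes the hydroxyl together, so the compounds shown do not separate the pyridine nitrogen from the loss of the hydroxyl and its halogen. Going by these compounds, a plain phenyl or a 2-hydroxyphenyl group at this position would bear on that question, and how far compound 4 lies past its limit stays open.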